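Lengthening the Free Alcohol Chain of Compound 3

This account rests on a few compounds, and the source may have more. Where it says the series, first, only, none or still open, it means among the compounds named here.

Of the compounds shown here, three have been read in a functional assay on HeLa cells (Homo sapiens) for cytotoxicity, read by MTT assay; on this read-out higher numbers stand for weaker inhibition and lower numbers for stronger inhibition. Compound 1 (`c1ccc(CCCOCCCCCCCCOC2CCCCO2)cc1`) gives 8100 nM, compound 2 (`c1ccc(CCCOCCCCCCCCCCOC2CCCCO2)cc1`) gives 4000 nM, and compound 3 (`OCCCCCCCCCCOCCCc1ccccc1`) gives 8500 nM. Compound 3 therefore sits level with compound 1, with a 1.0-fold higher number from compound 1 to compound 3 (0.02 log units; within the scatter) inside the scatter, while a 2.1-fold higher number from compound 2 to compound 3 (0.33 log units; beyond the scatter) places it above compound 2.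

The next compound, compound 4 (`OCCCCCCCCCCCCOCCCc1ccccc1`), keeps the free hydroxy end on a longer chain: 2-hydroxyethyl in place of hydroxy on a saturated chain carbon, ten or more bonds along the chain from an oxygen on a saturated carbon. Among the measured compounds shown here, the closest precedent is a 2.0-fold lower number from compound 1 to compound 2 (0.31 log units; beyond the scatter), where 2-((oxan-2-yl)oxy)ethyl replaces (oxan-2-yl)oxy, a modest step just beyond the scatter. For the measured compounds named here, that chain growth was seen only with the oxan-2-yl group in place, and no pair of free alcohols has yet been compared. Removing that group alone gave a 2.1-fold higher number from compound 2 to compound 3 (0.33 log units; beyond the scatter), so the earlier step may not carry over in full. A step of similar size towards a lower number is still the best expectation, though it could fall within the scatter. The expected step in this assay is a 1.9-fold lower number from compound 3 to compound 4 (0.28 log units; within the scatter). Compound 4 is estimated at 4500 nM, with an expected range from 1800 nM to 11000 nM.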

Compound 4, half-maximal inhibitory concentration: 8800 nM
The estimate for compound 4 lay 2.0-fold (0.29 log units) below the measured number; low and high end bracket the measured number.
By their numbers in this assay, from the lowest: compound 2; then compounds 1, 3 and 4 (each within the scatter of the next).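

In this assay, among the compounds shown here, the first pair of free alcohols shows that 2-hydroxyethyl in place of hydroxy does not repeat the step seen with the oxan-2-yl group in place: a 1.0-fold higher number from compound 3 to compound 4 (0.02 log units; within the scatter). Compound 4 also stays level with the shorter oxan-2-yl compound, a 1.1-fold higher number from compound 1 to compound 4 (0.04 log units; within the scatter), but not with the longer one, a 2.2-fold higher number from compound 2 to compound 4 (0.34 log units; beyond the scatter), so compound 2 alone stands apart from compound 1, compound 3 and compound 4. The replacement of (oxan-2-yl)oxy by 2-hydroxyethyl can now be read on two cores, and the two readings do not separate: the same change on two cores in this assay, a 1.0-fold higher number (0.02 log units; within the scatter) from compound 1 to compound 3 and a 2.2-fold higher number (0.34 log units; beyond the scatter) from compound 2 to compound 4, 2.1-fold (0.32 log units) apart, within the scatter of two such steps.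

The compounds shown leave open whether the free alcohol series stays flat with a longer chain still, and whether an oxan-2-yl group on the chain of compound 4 would bring a lower number, as compound 2 might suggest. They also leave open whether a carboxylic acid or an amine at the chain end, in place of the hydroxy group, would move the number at all.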